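Carbamoylpyridinyl Analogue in a Fatty-Acid Amide Hydrolase Series

This account rests on a few compounds, and the source may have more. Where it says the series, first, only, none or still open, it means among the compounds named here.

Three compounds sharing one core have been measured in an assay (Rattus norvegicus) for inhibition of Fatty-acid amide hydrolase 1 (Homo sapiens); on this read-out lower numbers stand for stronger inhibition and higher numbers for weaker inhibition:
compound 1 `NC(=O)c1cccc(-c2cnc(C(=O)CCCCCCc3ccccc3)o2)c1` gives 6 nM
compound 2 `COc1ccc(-c2cnc(C(=O)CCCCCCc3ccccc3)o2)cc1` gives 100 nM
compound 3 `N#Cc1ccc(-c2cnc(C(=O)CCCCCCc3ccccc3)o2)cc1` gives 40 nM

Compound 3 holds the second highest of these three numbers: a 2.5-fold lower number from compound 2 to compound 3 (0.40 log units; beyond the scatter), while a 6.7-fold higher number from compound 1 to compound 3 (0.82 log units; beyond the scatter). Compound 4 `NC(=O)c1cccc(-c2cnc(C(=O)CCCCCCc3ccccc3)o2)n1` differs from compound 3 by 6-carbamoylpyridin-2-yl in place of 4-cyanophenyl on an aromatic carbon. Among the measured compounds shown here, the step that bears most on this change is the one from compound 1 to compound 3, because a 6.7-fold higher number from compound 1 to compound 3 (0.82 log units; beyond the scatter) shows what happens when a 3-carbamoylphenyl is exchanged for a 4-cyanophenyl; compound 4 again carries a carbamoyl group, so the change from compound 3 largely reverses that step. For the measured compounds named here, the ring nitrogen that enters with the pyridinyl group appears in none of the measured compounds, and no step speaks to it. A modest step toward lower numbers is therefore expected, a 4.0-fold lower number from compound 3 to compound 4 (0.60 log units; beyond the scatter), without a firm basis for reaching compound 1. Compound 4 is estimated at 10 nM, with a range from 3 nM to 35 nM.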

Compound 4, inhibition constant: 1 nM
Compound 4: the middle estimate sits 10-fold (1.00 log units) above what was measured, and the stated range ends above it.
By their numbers in this assay, from the lowest: compound 4; then compound 1; then compound 3; then compound 2.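

In this assay, the ring nitrogen matters in its own right: with the carbamoyl group present in both compounds, the ring change alone gives a 6.0-fold lower number from compound 1 to compound 4 (0.78 log units; beyond the scatter). The carbamoyl group and the ring nitrogen together therefore take this position well past what the carbamoyl group gave on a carbon-only ring, with a 40-fold lower number from compound 3 to compound 4 (1.60 log units; beyond the scatter) and, against the methoxy-bearing ring, a 100-fold lower number from compound 2 to compound 4 (2.00 log units; beyond the scatter). Nothing available here explains why a single ring nitrogen makes this difference.

Going by these compounds, what remains open is whether the ring nitrogen needs the carbamoyl group at all, which a plain pyridin-2-yl ring, or a pyridine ring carrying a carboxylic acid in place of the carbamoyl group, would help to settle. The chain ending in phenyl is the same throughout, so it is also unknown whether these steps would hold with a shorter chain.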